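Hydroxy in place of methoxy on a cytotoxic pyrazole series

A few compounds are considered here, and "the series" means these few. Any claim that something is new, unique, unknown or untested is made for them only; others in the source may bear on it.

Measured compounds:
Compound 1 `COc1cc(C)cc(-c2c(-c3ccnc(-c4ccc(C(C)=O)cc4)c3)cnn2CC#N)c1` gives 97% in a functional assay on HCT-116 cells (Homo sapiens) for cytotoxicity, read by sulforhodamine B assay, with a stated time of 48 h, tested at 0.001 uM; a lower number here means a stronger effect, a higher number a weaker effect of the compound at the concentration tested.
Compound 2 `Cc1cc(O)cc(-c2nn(CC#N)cc2-c2ccnc(-c3ccc(Oc4ccccc4)cc3)c2)c1` gives 95% in this assay.
Compound 3 `COc1cc(C)cc(-c2nn(CC#N)cc2-c2ccnc(-c3ccc(N(C)C)cc3)c2)c1` gives 96% in this assay.

The three measured compounds lie close together. Compound 3 sits level with compound 1 and with compound 2, each of them within the usual scatter of it, so no order among the three can be claimed from these numbers.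

Compound 4 `Cc1cc(O)cc(-c2nn(CC#N)cc2-c2ccnc(-c3ccc(N(C)C)cc3)c2)c1` has not yet been measured. It differs from compound 3 in one place: hydrogen in place of methyl on an oxygen on an aromatic ring. Compound 2 already carries the hydroxy on that ring, alongside a different group at the far end, and compound 2 reads 95%, no different from the others beyond the scatter.

Among the measured compounds shown here, no step between measured compounds is available for this exact change, so the expectation rests on the closeness of the three values. The step from compound 3 to compound 4 in this assay is expected to be a number 1 percentage points lower from compound 3 to compound 4 (within the scatter), that is, none beyond the scatter. Compound 4 is therefore estimated at 95%, with a range from 86% to 100%.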

Compound 4, a percentage reported as activity, at one concentration (the size of the read-out at that concentration, not a potency): 95%
Compound 4: middle estimate and measured number agree at the digits printed; low and high end bracket the measured number.
By their numbers in this assay, from the lowest: compounds 2, 4, 3 and 1 (each within the scatter of the next).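

In this assay the swap of methoxy for hydroxy can now be read directly on a single pair, and a number 1 percentage points lower from compound 3 to compound 4 (within the scatter) shows that hydrogen in place of methyl on that oxygen leaves the read-out within the scatter with the dimethylamino group in place. The hydroxy can also now be followed with the far end changed, and no change at the digits printed from compound 2 to compound 4 (within the scatter) shows that dimethylamino in place of phenoxy makes no difference beyond the scatter either. Nothing available explains why these values lie so close together.

On these data alone, whether an amino group or a carboxylic acid in place of the hydroxy, or an ethoxy or longer alkoxy chain on that oxygen, would move the read-out beyond the scatter remains open. So does whether compound 3 and compound 4 would separate at any other concentration.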